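Predicting a benzyl-type amide in a melanocortin binding assay

The source may report more compounds than this note shows. Statements on the series, on what has been measured and on what is new or still open speak of the compounds shown alone.

Compound 2 `CC(C)C[C@H](N)c1cc(C(F)(F)F)ccc1N1CCN(C(=O)CNc2ccccc2)CC1` and compound 1 `CC(C)C[C@H](N)c1cc(C(F)(F)F)ccc1N1CCN(C(=O)COc2cccc3ccccc23)CC1` share a core and differ only in the group on the saturated chain carbon bound to the carbonyl. In a binding assay on HEK293 cells for displacement of a labelled ligand from Melanocortin receptor 4 (Homo sapiens) (a higher number here means a weaker inhibitor, a lower number a stronger inhibitor), compound 1 gives 2600 nM, and compound 2 gives 3600 nM; the change a 1.4-fold higher number from compound 1 to compound 2 (0.14 log units; within the scatter). Compound 2 thus holds the higher of two numbers, but within the scatter of compound 1. Compound 3 `Cc1cc(Cl)ccc1CC(C)C(=O)N1CCN(c2ccc(C(F)(F)F)cc2[C@@H](N)CC(C)C)CC1` carries a further change in the same place: 1-(4-chloro-2-methylbenzyl)ethyl in place of anilinomethyl on a carbonyl carbon. Within the data shown here, only that one measured step bears on it, and it was small. The expected step is a 1.2-fold lower number from compound 2 to compound 3 (0.08 log units; within the scatter), nothing beyond the scatter. Compound 3 is estimated at 3000 nM, with a range from 800 nM to 12000 nM.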

Compound 3, inhibition constant: 38 nM
Compound 3: middle estimate off by 79-fold (1.90 log units), on the high side, and the stated range ends above it.
By their numbers in this assay, from the lowest: compound 3; then compounds 1 and 2 (each within the scatter of the next).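

At this position on a carbonyl carbon, the choice of group can matter greatly in this assay: 1-(4-chloro-2-methylbenzyl)ethyl gives a 95-fold lower number from compound 2 to compound 3 (1.98 log units; beyond the scatter) and a 68-fold lower number from compound 1 to compound 3 (1.84 log units; beyond the scatter), although the two earlier groups lie within the scatter of each other. No available evidence accounts for steps of this size.

From the compounds shown here alone, because the new group differs from both earlier groups in several features at once, it remains open which of its parts matters. An unsubstituted benzyl group or a nitrile in place of the chlorine could help separate those contributions.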